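This account rests on a few compounds, and the source may have more. Where it says the series, first, only, none or still open, it means among the compounds named here.

Working notes on the series in a functional assay on MDA-MB-231 cells (Homo sapiens) for cytotoxicity, with a stated time of 48 h; on this read-out higher numbers stand for weaker inhibition and lower numbers for stronger inhibition. Compound 1 (`COc1cc(O)c(C(=O)/C=C/c2ccc(F)cc2)c(OC)c1`) gives > 20000 nM, a limit of the assay and not a number. For the measured compounds named here, compound 2 (`COc1cc(OC)c(C(=O)/C=C/c2ccccc2OC)c(OC)c1`) gives 13000 nM, the only true number so far. Compound 3 (`COc1cc(OC)c(C(=O)/C=C/c2ccccc2SC)c(OC)c1`) differs from compound 2 at a single place, ortho to a large group, with methylsulfanyl in place of methoxy on an aromatic carbon. Going by the values given here, no measured pair shows a single change, so the size of this step cannot be read from the data. With compound 2 at 13000 nM as the only anchor, no shift beyond the usual scatter is expected, and no direction is favoured. The expected step is a 1.1-fold lower number from compound 2 to compound 3 (0.03 log units; within the scatter). The estimate for compound 3 is 12000 nM, with an expected range of 5000 nM to 20000 nM.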

Compound 3, half-maximal inhibitory concentration: 9900 nM
Compound 3: middle estimate off by 1.2-fold (0.08 log units), on the high side, and the stated range covers the measured number.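

The series now has its first single-place pair: in this assay, methylsulfanyl in place of methoxy on an aromatic carbon, ortho to a large group, gives a 1.3-fold lower number from compound 2 to compound 3 (0.12 log units; within the scatter). At this position, the two groups, which match in the heavy-atom and hydrogen-bond acceptor counts, are not told apart by this read-out, as sulfur takes the place of oxygen with no shift beyond the usual scatter. Compound 1 differs from compound 2 in more than one place, and its value is a limit and not a number: the limit of > 20000 nM in this assay, at which 1 of the 3 values shown sits.

An amine, a carboxylic acid or a longer chain at this position would show whether any replacement here moves the number beyond the scatter. Going by these compounds, whether the same exchange behaves alike elsewhere on the ring remains open.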